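The source may report more compounds than this note shows. Statements on the series, on what has been measured and on what is new or still open speak of the compounds shown alone.

Of the compounds shown here, two sharing one core have been measured so far. In a functional assay on a cell-free system (Platelet, plasma, Oryctolagus cuniculus) for inhibition, with a stated time of 5 min (a lower number here means a stronger inhibitor, a higher number a weaker inhibitor), compound 1 (`CCOC(=O)/C=C/c1cc(OC)c(OCc2nc(C)c(C)nc2C)c(OC)c1`) gives 631000 nM, and compound 2 (`CCOC(=O)/C=C/c1ccccc1OCc1nc(C)c(C)nc1C`) gives 502000 nM. These two values lie within the scatter of each other, so the numbers do not separate compound 2 from compound 1. Compound 3 (`CCOC(=O)/C=C/c1cccc(OC)c1OCc1nc(C)c(C)nc1C`) departs from compound 2 in one place: methoxy in place of hydrogen on an aromatic carbon. Within the data shown here, no measured pair shows this change alone. Compound 1 also carries methoxy groups, and its 631000 nM stays within the scatter of the value of compound 2, so no change beyond the scatter is expected in this assay. The estimated step of a 1.0-fold lower number from compound 2 to compound 3 (0.00 log units; within the scatter) is accordingly expected to be negligible. For compound 3 the expected value is 500000 nM, within an estimated range of 250000 nM to 1000000 nM.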

Compound 3, half-maximal inhibitory concentration: > 2000000 nM
Compound 3 was reported as a limit; the forecaster's own chance of this, stated with the estimate: 10%; middle value at least 4.0-fold (0.60 log units) away from the limit.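

In this assay compound 3 gives > 2000000 nM, which is a limit of the assay and not a number. Among these compounds, the step, an at least 3.9-fold higher number from compound 2 to compound 3 (0.60 log units; beyond the scatter), is the first single-place change available, and it shows that methoxy in place of hydrogen on an aromatic carbon, ortho to a large group and meta to a 2-(ethoxycarbonyl)ethenyl group, weakens inhibition. Its full size cannot be read, only its lower bound, and the limit itself is shared by other values: the limit of > 2000000 nM in this assay, at which 1 of the 3 values shown sits.

As far as these compounds go, whether the same loss would follow from a fluorine atom, a methyl group or a hydroxy group at this position remains open. The compounds shown also leave open whether this methoxy group would have the same effect if a carboxylic acid replaced the ethyl ester.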